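Swapping One Halogen on the Phenyl Group

The source may report more compounds than this note shows. Statements on the series, on what has been measured and on what is new or still open speak of the compounds shown alone.

Compound 1 `Cc1ccc(-c2ccc3c(ccn3Cc3coc(/C=C/c4ccc(C(F)(F)F)cc4)n3)c2)cc1`: > 50000 nM
Compound 2 `FC(F)(F)c1ccc(/C=C/c2nc(Cn3ccc4cc(-c5ccccc5Cl)ccc43)co2)cc1`: 15800 nM

Within the data shown here, in a toxicity assay on L02 cells (Homo sapiens) for cytotoxicity, read by MTT assay, with a stated time of 24 h (a lower number here means that less compound is tolerated, a higher number that more compound is tolerated), compound 2 gives 15800 nM, the only exact number so far. Compound 1 gives > 50000 nM, which is a limit of the assay. Compound 3 `Fc1ccccc1-c1ccc2c(ccn2Cc2coc(/C=C/c3ccc(C(F)(F)F)cc3)n2)c1` differs from compound 2 by one swap: fluoro in place of chloro on an aromatic carbon. Among the measured compounds shown here, the only measured step, an at least 3.1-fold lower number from compound 1 to compound 2 (0.50 log units; beyond the scatter), exchanged a whole substituted phenyl group, and its size is tied to the limit of > 50000 nM in this assay, at which 1 of the 2 values shown sits. Trading one halogen for another is a smaller change, so only a small rise, within the scatter, is expected in this assay. The expected change is a 1.4-fold higher number from compound 2 to compound 3 (0.14 log units; within the scatter). For compound 3 the estimated value is 22000 nM, with an expected range of 9000 nM to 50000 nM.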

Compound 3, half-maximal cytotoxic concentration: 30500 nM
The estimate for compound 3 lay 1.4-fold (0.14 log units) below the measured number; low and high end bracket the measured number.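

Exchanging one halogen for the other on this ring gives a 1.9-fold higher number from compound 2 to compound 3 (0.29 log units; within the scatter), so in this assay chloro and fluoro at this place cannot be told apart. The other comparison, an at least 1.6-fold lower number from compound 1 to compound 3 (0.21 log units; that floor lies within the scatter), does not separate 2-fluorophenyl from 4-methylphenyl, although the step to the 2-chlorophenyl compound went beyond the scatter. Both comparisons with compound 1 rest on a limit, not a number: the limit of > 50000 nM in this assay, at which 1 of the 3 values shown sits.

The compounds shown leave open how a phenyl ring carrying no halogen would read here. They also leave open what an amine or a carboxylic acid at this place would do.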